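Compound 2 to compound 4: a ring exchange

The source may hold more compounds than are shown below. What is called first, only, known or untested is meant among the compounds shown, and "the series" means these compounds.

In a physicochemical assay for solubility (a lower number here means a less soluble compound, a higher number a more soluble compound), compound 2 `O=C1OCCN1c1cc(C(F)(F)F)ccc1[C@H]1CCOc2cc(S(=O)(=O)Nc3nccs3)ccc21` reads 295000 nM and sits within the scatter of compound 1 `CN1CCN(c2cc(C(F)(F)F)ccc2[C@H]2CCOc3cc(S(=O)(=O)Nc4nccs4)ccc32)CC1` at 176000 nM and of compound 3 `Cc1ccc(-c2cc(C(F)(F)F)ccc2[C@H]2CCOc3cc(S(=O)(=O)Nc4ncc(F)cn4)ccc32)cn1` at 225000 nM as well. Compound 4 `Cn1nccc1-c1cc(C(F)(F)F)ccc1[C@H]1CCOc2cc(S(=O)(=O)Nc3nccs3)ccc21` comes from compound 2 by one change: 1-methyl-1H-pyrazol-5-yl in place of 2-oxo-1,3-oxazolidin-3-yl on an aromatic carbon. Among the measured compounds shown here, the one measured step at this place stays within the scatter (a 1.7-fold higher number from compound 1 to compound 2 (0.22 log units; within the scatter)). Compound 3 also differs elsewhere, so its 225000 nM is only a loose guide. The expected step (a 1.5-fold lower number from compound 2 to compound 4 (0.17 log units; within the scatter)) therefore stays within the scatter in this assay too. For compound 4 the estimate is 200000 nM (expected range 90000 nM to 400000 nM).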

Compound 4, solubility: 83000 nM
Compound 4: middle estimate off by 2.4-fold (0.38 log units), on the high side; the measured number lies below the stated range.
By their numbers in this assay, from the lowest: compound 4; then compounds 1, 3 and 2 (each within the scatter of the next).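

In this assay this position, on an aromatic carbon meta to a trifluoromethyl group, now responds to the group it carries: a move to 1-methyl-1H-pyrazol-5-yl gives a 3.6-fold lower number from compound 2 to compound 4 (0.55 log units; beyond the scatter) and a 2.1-fold lower number from compound 1 to compound 4 (0.33 log units; beyond the scatter) in the two comparisons available. The earlier exchange of 4-methylpiperazin-1-yl for 2-oxo-1,3-oxazolidin-3-yl stayed within the scatter, so of these three groups only 1-methyl-1H-pyrazol-5-yl stands apart.

Nothing available explains this drop.
As far as these compounds go, whether a morpholine ring or a carboxylic acid here would read with compound 1 and compound 2 or with compound 4 stays open.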